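The source may report more compounds than this note shows. Statements on the series, on what has been measured and on what is new or still open speak of the compounds shown alone.

Compound 2 `Nc1cc(N)c2nc(-c3ccccc3)c(Sc3ccc(Cl)c(Cl)c3)nc2c1` shares its core with compound 1 `Nc1cc(N)c2nc(-c3ccccc3)c(NCc3ccc(F)cc3)nc2c1`. In a functional assay on COLO 205 cells (Homo sapiens) for inhibition, read by sulforhodamine B assay, with a stated time of 48 h (a higher number here means that more compound is tolerated, a lower number that less compound is tolerated), compound 1 gives only a limit of the assay, < 100000 nM. In this assay compound 2 likewise gives only a limit, < 100000 nM. Among the compounds with values here, the one measured step, a step that the two limits leave unreadable from compound 1 to compound 2, therefore stays unreadable, as both values sit at the limit of < 100000 nM in this assay, at which 2 of the 2 values shown sit. Compound 3 `Nc1cc(N)c2nc(-c3ccccc3)c(Oc3ccc(F)cc3)nc2c1` differs from compound 2 by 4-fluorophenoxy in place of (3,4-dichlorophenyl)sulfanyl on an aromatic carbon. Within the data shown here, no measured step bears on this change, so no direction beyond the scatter is expected, and the step from compound 2 to compound 3 is estimated at a step that the limit leaves unreadable from compound 2 to compound 3. Compound 3 is expected at 20000 nM, in the range 3000 nM to 100000 nM.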

Compound 3, concentration lethal to 50% of the cells: 66100 nM
For compound 3 the middle estimate is 3.3-fold (0.52 log units) below the measured one, within the range that was stated.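

No step to compound 3 can be read from compound 1 or compound 2, since both give only a limit: the limit of < 100000 nM in this assay, at which 2 of the 3 values shown sit.

On these data alone, whether 4-fluorophenoxy, (3,4-dichlorophenyl)sulfanyl and (4-fluorobenzyl)amino differ at this position on the shared core remains open.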